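Swapping propylsulfanyl for benzylamino

The source may hold more compounds than are shown below. What is called first, only, known or untested is meant among the compounds shown, and "the series" means these compounds.

Compound 1 `CNc1nc(N)nc2c1ncn2/C=C1/CC1(CO)CO`: 67000 nM
Compound 2 `CCCSc1nc(N)nc2c1ncn2/C=C1/CC1(CO)CO`: > 20000 nM (a limit)

In an ADME assay on BCBL1 cells (Homo sapiens) for cytotoxicity, with a stated time of 7 days (on this read-out lower numbers stand for higher toxicity in this test and higher numbers for lower toxicity in this test), compound 2 has no exact number, only the limit > 20000 nM. Compound 3 `Nc1nc(NCc2ccccc2)c2ncn(/C=C3/CC3(CO)CO)c2n1` carries benzylamino in place of propylsulfanyl on an aromatic carbon. Going by the values given here, the only measured step, a step that the limit leaves unreadable from compound 1 to compound 2, offers no size to carry over. Compound 1 is the nearer guide, since its methylamino group also links through nitrogen, and it gives 67000 nM. No clear direction can therefore be expected in this assay, and the estimated change is a step that the limit leaves unreadable from compound 2 to compound 3. For compound 3 the expected value is 35000 nM, with an estimated range of 10000 nM to 100000 nM.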

Compound 3, half-maximal cytotoxic concentration: 19900 nM
Compound 3: middle estimate off by 1.8-fold (0.25 log units), on the high side, and the stated range covers the measured number.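

In this assay, going by these compounds alone, phenyl on the saturated chain carbon of the methylamino group of compound 1 gives the first readable step at this position: a 3.4-fold lower number from compound 1 to compound 3 (0.53 log units; beyond the scatter). With the link through nitrogen kept, benzylamino therefore goes with higher toxicity in this test than methylamino, though this rests on a single pair. Benzylamino in place of propylsulfanyl gives a number no higher from compound 2 to compound 3 (the limit leaves the size open). Compound 2 has only a limit, so the size of its step to compound 3 cannot be read: the limit of > 20000 nM in this assay, at which 1 of the 3 values shown sits.

From the compounds shown here alone, it remains open whether the aromatic ring is what counts, since a cyclohexylmethylamino group would be needed to test that. Going by these compounds, how a phenethylamino group at this carbon would compare also remains open.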